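From 2-fluorobenzyl to 2-chlorobenzyl: compound 2 to compound 3

This account rests on a few compounds, and the source may have more. Where it says the series, first, only, none or still open, it means among the compounds named here.

Measured in a functional assay on DU-145 cells (Homo sapiens) for cytotoxicity, read by MTT assay, with a stated time of 24 h; a lower number here means a stronger inhibitor, a higher number a weaker inhibitor:
Compound 1 `Cc1ccc(/C=C2\CN(C(=S)SCc3cn(Cc4cccc(Cl)c4)nn3)C/C(=C\c3ccc(C)cc3)C2=O)cc1`: > 80000 nM (a limit of the assay)
Compound 2 `Cc1ccc(/C=C2\CN(C(=S)SCc3cn(Cc4ccccc4F)nn3)C/C(=C\c3ccc(C)cc3)C2=O)cc1`: 80000 nM

In this assay, for the measured compounds named here, compound 2 gives 80000 nM, the only true number available. The value for compound 1 is only a limit, and the series offers no second number for comparison. (the limit of > 80000 nM in this assay, at which 1 of the 2 values shown sits).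

Compound 3 `Cc1ccc(/C=C2\CN(C(=S)SCc3cn(Cc4ccccc4Cl)nn3)C/C(=C\c3ccc(C)cc3)C2=O)cc1` carries chloro in place of fluoro on an aromatic carbon, ortho to a large group, and the rest of its structure matches compound 2: chloro in place of fluoro on an aromatic carbon. Going by the values given here, the one measured step bears on this only loosely, as it also exchanges a halogen on the same benzyl group: a number no higher from compound 1 to compound 2 (the limit leaves the size open). Its size cannot be read, so it gives no basis for expecting a shift in either direction. No step beyond the scatter is therefore expected, and the expected no change at the digits printed from compound 2 to compound 3 (within the scatter) is small. Compound 3 may also be reported only as a limit. For compound 3 the estimated value is 80000 nM, with an expected range of 30000 nM to 160000 nM.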

Compound 3, half-maximal inhibitory concentration: > 80000 nM
Compound 3 gave a limit, no number; the forecaster's own chance of this, stated with the estimate: 50%; the middle value sits exactly at the limit.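

With chloro in place of fluoro on an aromatic carbon ortho to a large group, compound 3 is reported in this assay only as a limit of the assay, > 80000 nM. Read as a step, this exchange gives a number no lower from compound 2 to compound 3 (the limit leaves the size open) and no more. The steps that involve compound 3 therefore cannot be read in size, and the halogen exchange at this position shows no measurable gain in this assay. Most of the series now sits at a ceiling of the assay rather than at comparable numbers: the limit of > 80000 nM in this assay, at which 2 of the 3 values shown sit.

The compounds shown leave open whether this position can give a readable change at all, since compound 2 still holds the only true number. Nor do they show how an amine or a methoxy group in place of the halogen, or a longer chain in place of the 2-chlorobenzyl group, would read in this assay.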